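The source may report more compounds than this note shows. Statements on the series, on what has been measured and on what is new or still open speak of the compounds shown alone.

Measured so far in an ADME assay on cells (Splenocyte, Mus musculus, strain BALB/c) for cytotoxicity, read by CCK-8 assay, with a stated time of 48 h; a higher number here means that more compound is tolerated, a lower number that less compound is tolerated:
compound 1 `CCCCc1nc(Cc2c[nH]c3ccccc23)no1` — > 50000 nM
compound 2 `COc1cc(-c2noc(-c3ccc(NC(=O)OC(C)(C)C)cc3)n2)cc(OC)c1OC` — 9200 nM
compound 3 `COc1cc(-c2noc(C3CC4(C3)CC(F)(F)C4)n2)cc(OC)c1OC` — 28500 nM

The value of compound 1 is a limit of the assay, not a number (the limit of > 50000 nM in this assay, at which 1 of the 3 values shown sits). Among the two numbers, compound 2 stands lowest: compound 3 sits nearest to it, with a higher number that lies beyond the usual scatter, so compound 3 is tolerated at a higher concentration than compound 2. Going by the values given here, no pair of measured compounds differs in just one place, so no measured single step is available to anchor the change considered here.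

Compound 4 `CCCCCCc1ccc(-c2nc(-c3cc(OC)c(OC)c(OC)c3)no2)cc1` has not yet been measured in this assay. It differs from compound 2 as follows: hexyl in place of (tert-butoxycarbonyl)amino on an aromatic carbon. Among the compounds with values here, with no measured step of this kind to point to, the expectation is a step from compound 2 to compound 4 in this assay of no more than the usual scatter, in no clear direction, with a wider band to either side. Compound 4 is estimated at 8000 nM in this assay, within 3000 nM to 25000 nM, which means an expected step of a 1.2-fold lower number from compound 2 to compound 4 (0.06 log units; within the scatter).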

Compound 4, half-maximal cytotoxic concentration: 25000 nM
Compound 4: middle estimate off by 3.1-fold (0.49 log units), on the low side, within the range that was stated.
By their numbers in this assay, from the lowest: compound 2; then compounds 4 and 3 (each within the scatter of the next). At a limit, above all of these: compound 1.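

Going by these compounds alone, at this position, on an aromatic carbon para to a large group, the series now has its one measured single change: in this assay, hexyl in place of (tert-butoxycarbonyl)amino gives a 2.7-fold higher number from compound 2 to compound 4 (0.43 log units; beyond the scatter), a modest step toward more compound being tolerated. The (tert-butoxycarbonyl)amino group, with its carbonyl and hydrogen-bond donor, is therefore not needed for tolerance at this level, since hexyl carries no hydrogen-bond donor or acceptor. Nothing measured here gives a reason for this step.

As far as these compounds go, it remains open whether the step follows from losing the (tert-butoxycarbonyl)amino group or from gaining hexyl, which a free amine, a carboxylic acid or a shorter chain such as propyl at this place could separate. Within the data shown here, whether the same change holds on another core also remains open, as this single pair is the only reading.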